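The source may report more compounds than this note shows. Statements on the series, on what has been measured and on what is new or still open speak of the compounds shown alone.

Of the compounds shown here, two built on one shared core have been measured so far. Compound 1 `COc1ccc2nc(-c3ccc(O)cc3O)c(=O)n(CC(=O)O)c2c1` and compound 2 `COc1ccc2nc(/C=C/c3ccc(O)cc3)c(=O)n(CC(=O)O)c2c1` were both tested in a functional assay, with a stated time of 240 min, tested at 100 uM; a higher number here means a stronger effect of the compound at the concentration tested, a lower number a weaker effect. In this assay compound 1 gives 37.2%. In this assay compound 2 gives 59.2%, the higher of the two numbers, and its gap to compound 1 is beyond the scatter, so compound 2 stands at the top of what has been measured. A third member, compound 3 `COc1ccc2nc(/C=C/c3ccc(O)c(OC)c3)c(=O)n(CC(=O)O)c2c1`, has not yet been measured. It differs from compound 2 in a single place: methoxy in place of hydrogen on an aromatic carbon. Within the data shown here, no measured pair in this set shows that change, so nothing here tells how large its effect is or in which direction it runs. The step expected in this assay, a number 4.2 percentage points lower from compound 2 to compound 3 (within the scatter), is therefore small and most likely lies within the scatter, with no clear direction. On that basis compound 3 is estimated to give 55% in this assay, with a range from 35% to 72%.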

Compound 3, a percentage reported as activity, at one concentration (the size of the read-out at that concentration, not a potency): 83.5%
The estimate for compound 3 lay 28.5 percentage points below the measured number; the measured number lies above the stated range.
By their numbers in this assay, from the lowest: compound 1; then compound 2; then compound 3.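

Among these compounds, the first pair in this set to show methoxy in place of hydrogen gives a number 24.3 percentage points higher from compound 2 to compound 3 (beyond the scatter) in this assay, so this aromatic carbon, ortho to a hydroxy group and meta to a large group, is not indifferent to substitution. Going from 4-hydroxyphenyl to 4-hydroxy-3-methoxyphenyl, a change of only 2 heavy atoms with no ring and no net charge, strengthens the effect at the concentration tested, and the direction of this change is now known for this one pair. No measurement shown here accounts for the gain, so its origin stays unexplained.

This single pair cannot separate the methoxy group itself from any other substituent on that carbon, such as an ethoxy group, a second hydroxy group, a fluorine atom or an amine, nor show whether the gain depends on the hydroxy group it sits ortho to. Going by these compounds, the read-out also comes from one concentration, so it gives the size of the effect there rather than a potency, and how the step would carry over to other compounds on the shared core remains open.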